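The source may hold more compounds than are shown below. What is called first, only, known or untested is meant among the compounds shown, and "the series" means these compounds.

Measured so far:
Compound 1, `O=C(CCCCCc1ccccc1)c1nc2ncccc2[nH]1`, gives 1230 nM in an assay on HEK-293T cells for inhibition of diacylglycerol lipase-alpha (Homo sapiens), read by colorimetric assay; a higher number here means a weaker inhibitor, a lower number a stronger inhibitor.
Compound 2, `O=C(CCCCCc1ccccc1)c1nc2ccc([N+](=O)[O-])cc2o1`, gives 87.1 nM in this assay.
Compound 3, `O=C(CCCCCCc1ccccc1)c1nc(-c2ccco2)no1`, gives 933 nM in this assay.

Compound 3 stands second highest of these three numbers. Its nearest neighbour is compound 1, whose number lies within the usual scatter of that of compound 3, so the two cannot be told apart. Compound 2 gives a number well below that of compound 3, a gap that lies beyond the scatter.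

Compound 4, `O=C(CCCCCCc1ccccc1)c1nc(-c2cccc(Cl)n2)no1`, differs from compound 3 in one place: 6-chloropyridin-2-yl in place of furan-2-yl on an aromatic carbon. Going by the values given here, no measured pair shows this exchange, so its effect in this assay is unknown. A step of modest size is expected, if anything toward a lower number, and it may well stay within the scatter; the step from compound 3 to compound 4 is estimated at a 1.6-fold lower number from compound 3 to compound 4 (0.19 log units; within the scatter). For compound 4 a value of 600 nM is expected, in the range 150 nM to 2500 nM.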

Compound 4, half-maximal inhibitory concentration: > 10000 nM
Compound 4: no number, only a limit; the forecaster's own chance of this, stated with the estimate: 5%; at least 16-fold (1.22 log units) between middle value and limit.
By their numbers in this assay, from the lowest: compound 2; then compounds 3 and 1 (each within the scatter of the next). At a limit, above all of these: compound 4.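

Compound 4 reads in this assay only as a limit, not as a number: the limit of > 10000 nM in this assay, at which 1 of the 4 values shown sits. Going by these compounds alone, the exchange of furan-2-yl for 6-chloropyridin-2-yl gives an at least 10-fold higher number from compound 3 to compound 4 (1.03 log units; beyond the scatter), the first step here between compounds that differ in one place, and it shows that the aromatic carbon between two ring nitrogen atoms does not take these two aromatic rings alike. The two groups have the same counts of hydrogen-bond donors and acceptors and no net charge, so those counts do not separate them; they differ in ring size, in the ring hetero atom and in the chlorine.

The compounds shown leave open which of these differences carries the step, as a plain pyridin-2-yl or a phenyl ring would help to tell. They also leave open how an amine on this carbon would read.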